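The source may report more compounds than this note shows. Statements on the series, on what has been measured and on what is new or still open speak of the compounds shown alone.

In an ADME assay on BCBL1 cells (Homo sapiens) for cytotoxicity, with a stated time of 7 days (on this read-out lower numbers stand for higher toxicity in this test and higher numbers for lower toxicity in this test), three compounds have been measured so far, and each reading is a limit:

Compound 1 `CN(C)c1nc(N)nc2c1ncn2/C=C1/CC1(CO)CO`: > 20000 nM
Compound 2 `CCCCCCCCSc1nc(N)nc2c1ncn2/C=C1/CC1(CO)CO`: > 20000 nM
Compound 3 `Nc1nc(NC2CCCCC2)c2ncn(/C=C3/CC3(CO)CO)c2n1`: > 20000 nM

Compound 3 gives only a limit, > 20000 nM, so no number fixes its place. The other two compounds share that position, and the overall picture is the limit of > 20000 nM in this assay, at which 3 of the 3 values shown sit.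

The next compound, compound 4 `CC(C)CNc1nc(N)nc2c1ncn2/C=C1/CC1(CO)CO`, keeps the shared core and changes one group: isobutyl in place of cyclohexyl on a nitrogen on an aromatic ring. In short, cyclohexylamino gives way to isobutylamino.

The measured steps that bear on this change all concern the same aromatic carbon: a step that the two limits leave unreadable from compound 1 to compound 3, a step that the two limits leave unreadable from compound 2 to compound 3 and a step that the two limits leave unreadable from compound 1 to compound 2. None has a readable size, so there is no measured magnitude to carry over. They show only that dimethylamino, octylsulfanyl and cyclohexylamino all leave the reading at the limit in this assay, and none of the three measured compounds goes against this. No step beyond the scatter is therefore expected in either direction, and another limit is the likeliest result.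

The expected size of the change is estimated as a step that the limit leaves unreadable from compound 3 to compound 4.

Compound 4 is estimated at 25000 nM, with an expected range from 12000 nM to 50000 nM.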

Compound 4, half-maximal cytotoxic concentration: > 20000 nM
Compound 4: no number, only a limit (the forecaster's own chance of this, stated with the estimate: 85%); the middle value does not contradict the limit.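

In this assay compound 4 gives > 20000 nM, which is a limit and not a number. Its steps from compound 1, compound 2 and compound 3 cannot be read. The overall picture is unchanged: the limit of > 20000 nM in this assay, at which 4 of the 4 values shown sit.

The compounds shown leave open whether these groups on the aromatic carbon differ at all in this read-out.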